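Adding a methyl to the pyridinyl ether of compound 3

The source may report more compounds than this note shows. Statements on the series, on what has been measured and on what is new or still open speak of the compounds shown alone.

Compound 3 (`Cn1c(COc2cccc(C(=O)O)c2)nc2ccc(Oc3ccccn3)cc21`) reads 0.4 in a physicochemical assay for lipophilicity, read by LC-MS, in phosphate buffer, measured as octanol-water partition, with a stated time of 30 min, at pH 7.4, tested at 200 mM (a lower number here means a more polar compound, a higher number a more lipophilic compound), and is the lowest of the three measured compounds. Compound 2 (`Cc1ccc(Oc2cc3c(cn2)nc(COc2cccc(C(=O)O)c2)n3C)cc1`) is the nearest at 1 and compound 1 (`Cc1ccc(Oc2ccc3nc(COc4cccc(C(=O)O)c4)n(C)c3n2)cc1F`) the furthest at 2.1 with both gaps beyond the scatter.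

Compound 4 (`Cc1ccc(Oc2ccc3nc(COc4cccc(C(=O)O)c4)n(C)c3c2)nc1`) has not yet been measured and differs from compound 3 in one place. The change methyl in place of hydrogen on an aromatic carbon turns (pyridin-2-yl)oxy into (5-methylpyridin-2-yl)oxy, with methyl in place of hydrogen on an aromatic carbon, two atoms from the ring nitrogen and para to a large group. Going by the values given here, no two measured compounds differ in one place only, so the series gives no direct measure of this change, and the expectation rests on the structural change alone. A modest upward step is expected in this assay and is estimated as a number 0.50 log units higher from compound 3 to compound 4 (beyond the scatter) for now. For compound 4 the estimated value is 0.9 with an expected range from 0.5 to 1.3 pending measurement.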

Compound 4, distribution coefficient: 0.9
Beside the measured number, compound 4's estimate shows no gap at the digits printed; the measured number falls inside the stated range.
By their numbers in this assay, from the lowest: compound 3; then compounds 4 and 2 (each within the scatter of the next); then compound 1.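

The series now holds its first step between compounds that differ in one place: methyl in place of hydrogen on an aromatic carbon of the pyridin-2-yl ring, two atoms from the ring nitrogen and para to a large group, gives in this assay a number 0.50 log units higher from compound 3 to compound 4 (beyond the scatter) as its reading. A single added heavy atom at this position is therefore enough to move the number past the usual scatter. Nothing available explains the size of this step.

Going by these compounds, one step at one position sets no trend, and how the number responds to a longer chain such as ethyl, or to chloro or methoxy, on this same carbon remains open. Also open, on these data alone, is whether the same methyl gives a step of similar size on the other carbons of this ring or on a different core.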